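The source may hold more compounds than are shown below. What is called first, only, known or untested is meant among the compounds shown, and "the series" means these compounds.

Measured in a functional assay on U-251 cells (Homo sapiens) for cytotoxicity; on this read-out lower numbers stand for stronger inhibition of growth and higher numbers for weaker inhibition of growth:
- compound 1 `COc1ccc(C2=C(c3cc(OC)c(OC)c(OC)c3)CC3CCCN3C2=O)cc1O`: > 100000 nM (a limit)
- compound 2 `COc1ccc(C2=C(c3ccc(SC)cc3)CC3CCCN3C2=O)cc1`: 2000 nM
- compound 3 `CSc1ccc(C2=C(c3ccc(O)cc3)C(=O)N3CCCC3C2)cc1`: > 100000 nM (a limit)

Compound 3 has no exact number in this assay. Its > 100000 nM is a limit. This is the limit of > 100000 nM in this assay, at which 2 of the 3 values shown sit, so only compound 2 has a true number.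

Compound 4 `CSc1ccc(C2=C(c3ccc(SC)cc3)C(=O)N3CCCC3C2)cc1` has not yet been measured. It differs from compound 3 in one place: methylsulfanyl in place of hydroxy on an aromatic carbon. In words, methylsulfanyl stands in place of hydroxy on an aromatic carbon, para to a large group.

For the measured compounds named here, one measured step bears on this same place: an at least 50-fold higher number from compound 2 to compound 3 (1.69 log units; beyond the scatter). That large step is what introduced the hydroxy group, and compound 4 loses it again. Compound 1 also carries a hydroxy group on an aromatic ring, but it differs from compound 3 in too many other places to serve as a step.

Going by these compounds, compound 4 is therefore expected to move back toward compound 2, although methylsulfanyl at this place is untested and a return may be only partial. The expected change is an at least 33-fold lower number from compound 3 to compound 4 (1.52 log units; beyond the scatter), a large step toward stronger growth inhibition. For compound 4, the estimated value is 3000 nM, with an expected range of 500 nM to 30000 nM.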

Compound 4, concentration for 50% growth inhibition: 5000 nM
For compound 4 the middle estimate is 1.7-fold (0.22 log units) below the measured one; measured number inside the range.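

In this assay, the loss seen with the hydroxy group can be reversed by a group other than the methoxy of compound 2: methylsulfanyl at this place gives an at least 20-fold lower number from compound 3 to compound 4 (1.30 log units; beyond the scatter). So this place on the aromatic ring accepts more than one group without the growth inhibition vanishing, but the two groups that work are not equal, with a 2.5-fold higher number from compound 2 to compound 4 (0.40 log units; beyond the scatter), a modest change that still lies beyond the scatter. Compound 3 gives > 100000 nM, which is a limit, so the step from it is a minimum and not an exact size, and exact comparison at this place rests on compound 2 and compound 4 alone: the limit of > 100000 nM in this assay, at which 2 of the 4 values shown sit.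

The compounds shown leave open how an amine, a carboxylic acid or a longer chain such as ethylsulfanyl would fare at this place, so it is unclear how far the tolerance reaches beyond methoxy and methylsulfanyl. They also leave open whether the same order of groups would hold on the core of compound 1, which differs from these compounds in more than one place.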